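Swapping the aryl arm for a pyridine in a reductase inhibitor

The source may hold more compounds than are shown below. What is called first, only, known or untested is meant among the compounds shown, and "the series" means these compounds.

Measured compounds:
- compound 1, `CCC(c1ccccc1)n1ccc2cc(/C(C)=C/C(=O)Nc3ccccc3OCCCC(=O)O)ccc21`: 19 nM
- compound 2, `C/C(=C\C(=O)Nc1ccccc1OCCCC(=O)O)c1ccc2c(ccn2C(c2ccccc2)C(C)C)c1`: 25 nM
- compound 3, `C/C(=C\C(=O)Nc1ccccc1OCCCC(=O)O)c1ccc2c(ccn2C(c2ccccc2)c2ccc(C(F)(F)F)cc2)c1`: 8.1 nM

All three share one core and differ only in the group attached to the saturated chain carbon bound to an aromatic carbon and an aromatic nitrogen. In an assay on Prostate gland for inhibition of steroid 5-alpha-reductase (Rattus norvegicus) (on this read-out higher numbers stand for weaker inhibition and lower numbers for stronger inhibition), compound 3 gives 8.1 nM, the lowest of the three numbers. Its nearest neighbour is compound 1, and the step of a 2.3-fold lower number from compound 1 to compound 3 (0.37 log units; beyond the scatter) lies beyond the scatter; the step of a 3.1-fold lower number from compound 2 to compound 3 (0.49 log units; beyond the scatter) is larger still. Between compound 1 and compound 2 the step of a 1.3-fold higher number from compound 1 to compound 2 (0.12 log units; within the scatter) is within the scatter.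

Compound 4, `C/C(=C\C(=O)Nc1ccccc1OCCCC(=O)O)c1ccc2c(ccn2C(c2ccccc2)c2cccnc2)c1`, is not yet measured. It differs from compound 3 in one place: pyridin-3-yl in place of 4-(trifluoromethyl)phenyl on a saturated chain carbon bound to an aromatic carbon and an aromatic nitrogen. For the measured compounds named here, no measured step exchanges one aromatic ring for another at this position; the two measured steps reaching compound 3 only show that an aromatic group there gave a lower number than a small saturated one. A ring is kept, so a number nearer compound 3 than compound 2 is expected, with some loss. Compound 4 is therefore expected at 15 nM, within 6 nM to 40 nM, an expected step of a 1.9-fold higher number from compound 3 to compound 4 (0.27 log units; within the scatter) in this assay.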

Compound 4, half-maximal inhibitory concentration: 47 nM
Estimate against measurement, compound 4: 3.1-fold (0.50 log units) below; measured number above the stated range.
By their numbers in this assay, from the lowest: compound 3; then compounds 1, 2 and 4 (each within the scatter of the next, the first and the last beyond it).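

In this assay, this first exchange of one aromatic ring for another at this position gives a 5.8-fold higher number from compound 3 to compound 4 (0.76 log units; beyond the scatter) and shows that keeping a ring is not enough to keep the number low: which ring is present matters. Pyridin-3-yl also lacks the clear edge that 4-(trifluoromethyl)phenyl showed over the saturated groups, with a 1.9-fold higher number from compound 2 to compound 4 (0.27 log units; within the scatter) against isopropyl and a 2.5-fold higher number from compound 1 to compound 4 (0.39 log units; beyond the scatter) against ethyl, so here the ring gives no gain over either group. Nothing in the data shown explains the difference between the two rings.

Still open, going by these compounds, is whether the higher number goes with the ring nitrogen or with the missing trifluoromethyl group, and a plain phenyl at this place would help separate the two. Pyridin-2-yl and pyridin-4-yl would show whether the nitrogen's place in the ring changes the number.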